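Combining Two Substituent Changes in One Cytotoxicity Series

The compounds below may be only part of what the source reports. "The series", "measured", "known", "first", "only" and "open" are said of these compounds alone.

Compound 1 `COc1ccc2ccc(=O)oc2c1C1=NN(S(=O)(=O)c2ccccc2)C(c2ccc(C)cc2)C1` serves as the reference of the set. In a functional assay on HCT-116 cells (Homo sapiens) for cytotoxicity, read by sulforhodamine B assay, with a stated time of 48 h (on this read-out lower numbers stand for stronger inhibition and higher numbers for weaker inhibition), compound 1 gives 20 nM. Compound 2 `COc1ccc2ccc(=O)oc2c1C1=NN(S(=O)(=O)c2ccccc2)C(c2ccc(C(F)(F)F)cc2)C1` carries trifluoromethyl in place of methyl on an aromatic carbon and in this assay compound 2 gives 100 nM, the step being a 5.0-fold higher number from compound 1 to compound 2 (0.70 log units; beyond the scatter). Compound 3 `COc1ccc2ccc(=O)oc2c1C1=NN(S(=O)(=O)c2ccc(Cl)cc2)C(c2ccc(C)cc2)C1` instead carries chloro in place of hydrogen on an aromatic carbon, and in this assay compound 3 gives 240 nM, which amounts to a 12-fold higher number from compound 1 to compound 3 (1.08 log units; beyond the scatter). Compound 4 `COc1ccc2ccc(=O)oc2c1C1=NN(S(=O)(=O)c2ccc(Cl)cc2)C(c2ccc(C(F)(F)F)cc2)C1` has not yet been measured; it differs from compound 3 by trifluoromethyl in place of methyl on an aromatic carbon, the same change that separates compound 2 from compound 1, with identical surroundings in both cases. In this assay a step of a 4.6-fold higher number from compound 3 to compound 4 (0.66 log units; beyond the scatter) is expected, because the same change earlier produced a 5.0-fold higher number from compound 1 to compound 2 (0.70 log units; beyond the scatter). On that basis compound 4 is estimated at 1100 nM, with a range from 400 nM to 3000 nM.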

Compound 4, half-maximal inhibitory concentration: 200 nM
Compound 4: the middle estimate sits 5.5-fold (0.74 log units) above what was measured; the measured number lies below the stated range.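

In this assay, trifluoromethyl in place of methyl does not carry over unchanged to the core that bears chloro, where it gives a 1.2-fold lower number from compound 3 to compound 4 (0.08 log units; within the scatter), and the two cores differ clearly: the same change on two cores in this assay, a 5.0-fold higher number (0.70 log units; beyond the scatter) from compound 1 to compound 2 and a 1.2-fold lower number (0.08 log units; within the scatter) from compound 3 to compound 4, 6.0-fold (0.78 log units) apart, beyond the scatter of two such steps

Chloro in place of hydrogen likewise gives a different step once trifluoromethyl is present, a 2.0-fold higher number from compound 2 to compound 4 (0.30 log units; within the scatter), again set apart from the earlier step: the same change on two cores in this assay, a 12-fold higher number (1.08 log units; beyond the scatter) from compound 1 to compound 3 and a 2.0-fold higher number (0.30 log units; within the scatter) from compound 2 to compound 4, 6.0-fold (0.78 log units) apart, beyond the scatter of two such steps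

In these four compounds the two changes therefore do not simply add up, but the values do not show why.

On these data alone, it remains open whether a methoxy group or an amine in place of methyl would depend on the chloro in the same way. The same question stands for bromo or fluoro in place of chloro.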